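The source may report more compounds than this note shows. Statements on the series, on what has been measured and on what is new or still open speak of the compounds shown alone.

Compounds in a functional assay on HL-60 cells (Homo sapiens) for cytotoxicity, read by WST assay, with a stated time of 48 h (a higher number here means that more compound is needed for the effect, a lower number that less compound is needed), so far are compound 1, `COc1cccc(C[C@H]2COC(=O)[C@@H]2Cc2ccc(Cl)c(Cl)c2)c1`, which gives 34000 nM, and compound 2, `Cc1cccc(C[C@H]2COC(=O)[C@@H]2Cc2ccc(Cl)c(Cl)c2)c1`, which gives 22000 nM. Compound 2 holds the lowest of the two numbers, and its nearest neighbour is compound 1, the pair being separated only by a 1.5-fold lower number from compound 1 to compound 2 (0.19 log units; within the scatter), a change of methyl for methoxy on an aromatic carbon that stays within the scatter. Compound 3, `O=C1OC[C@H](Cc2ccc(Cl)c(Cl)c2)[C@H]1Cc1ccc(Cl)c(Cl)c1`, is not yet measured; relative to compound 2 the difference is 3,4-dichlorophenyl in place of 3-methylphenyl on a saturated chain carbon bound to a saturated ring carbon. Among the compounds with values here, the single measured step concerns the same aromatic ring but exchanges one small group for another, and it moved the number within the scatter only; no measured step exchanges the whole 3-methylphenyl for a 3,4-dichlorophenyl, so the expectation rests on little. The step expected is a 1.5-fold lower number from compound 2 to compound 3 (0.17 log units; within the scatter), a modest lowering that may well sit within the scatter. Compound 3 is therefore estimated at 15000 nM, with a range from 5000 nM to 45000 nM.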

Compound 3, half-maximal effective concentration: 20000 nM
The estimate for compound 3 lay 1.3-fold (0.12 log units) below the measured number, within the range that was stated.
By their numbers in this assay, from the lowest: compounds 3, 2 and 1 (each within the scatter of the next).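

In this assay, the exchange of the whole aromatic group on a saturated chain carbon bound to a saturated ring carbon gives a 1.1-fold lower number from compound 2 to compound 3 (0.04 log units; within the scatter), and the same exchange starting from 3-methoxyphenyl gives a 1.7-fold lower number from compound 1 to compound 3 (0.23 log units; within the scatter). Earlier, only a small group on this ring had been exchanged; now 3,4-dichlorophenyl, with its two chlorine atoms, also stays within the scatter of both 3-methylphenyl and 3-methoxyphenyl, so these three groups are not told apart at this place. No measurement available bears on the reason for this result.

Going by these compounds, whether an amine or a carboxylic acid on this ring, or a longer chain in place of the ring, would carry the number beyond the scatter remains open. The compounds shown also leave open how far this result holds with another group in place of the 3,4-dichlorophenyl kept on the other side of the core.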